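Methyl on the Sulfonamide Nitrogen of Compound 1

The source may report more compounds than this note shows. Statements on the series, on what has been measured and on what is new or still open speak of the compounds shown alone.

For the measured compounds named here, compound 1 `CCCCNc1ccc(C(=O)O)cc1S(=O)(=O)NC` gives 6.4% in an assay on HEK293 cells for inhibition of solute carrier family 12 member 2 (Homo sapiens), read by fluorescence, with a stated time of 30 min, tested at 10 uM (on this read-out higher numbers stand for a stronger effect at the one concentration tested and lower numbers for a weaker effect), the low end of the two numbers known so far, though within the scatter of its one measured neighbour. That neighbour, compound 2 `CCCCCCCCNc1ccc(C(=O)O)cc1S(=O)(=O)NC`, gives 16.2% in this assay. Going by the values given here, the only measured step, a number 9.8 percentage points higher from compound 1 to compound 2 (within the scatter), alters the chain four bonds from the nitrogen on the aromatic ring and does not rise beyond the scatter. Compound 3 `CCCCNc1ccc(C(=O)O)cc1S(=O)(=O)N(C)C` differs from compound 1 elsewhere: methyl in place of hydrogen on a sulfonamide nitrogen. Among the compounds with values here, no measured step touches the sulfonamide nitrogen, so the known step offers little guidance, and it was itself too small to show a direction. No change beyond the scatter is therefore expected in this assay. Compound 3 is expected to give 8%, with a range from 0% to 20%. The expected step is a number 1.6 percentage points higher from compound 1 to compound 3 (within the scatter).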

Compound 3, a percentage reported as inhibition, at one concentration (the size of the read-out at that concentration, not a potency): 2.6%
Estimate against measurement, compound 3: 5.4 percentage points above; low and high end bracket the measured number.
By their numbers in this assay, from the lowest: compounds 3, 1 and 2 (each within the scatter of the next, the first and the last beyond it).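

For the compounds shown here, this is the first step at the sulfonamide nitrogen, and in this assay putting methyl in place of hydrogen there gives a number 3.8 percentage points lower from compound 1 to compound 3 (within the scatter) and so no change that can be told from the scatter. Going from methylsulfamoyl to dimethylsulfamoyl therefore does not show that the remaining hydrogen on this nitrogen matters to the read-out, although compound 1, at 6.4% in this assay, already sits so low that a further loss would be hard to see. No available evidence bears on this result.

From the compounds shown here alone, it remains open what a larger group on this nitrogen, such as benzyl, would do, or a sulfonamide nitrogen carrying two hydrogens. Also open, going by these compounds, is whether dimethylsulfamoyl would give a similar result on the longer chain of compound 2, which starts from 16.2% in this assay.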